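Hydrazone aryl swap on a thiazole acylurea series

This account rests on a few compounds, and the source may have more. Where it says the series, first, only, none or still open, it means among the compounds named here.

Measured compounds in a functional assay on MCF7 cells (Homo sapiens) for inhibition, read by MTT assay, with a stated time of 72 h; on this read-out higher numbers stand for weaker inhibition and lower numbers for stronger inhibition:
- compound 1, `CN(C(=O)NC(=O)c1cccc(C(F)(F)F)c1)c1nc(C(F)(F)F)c(C(=O)N/N=C/c2ccccc2C(F)(F)F)s1`: 7.69 ug/mL
- compound 2, `CN(C(=O)NC(=O)c1ccc(F)c(F)c1)c1nc(C(F)(F)F)c(C(=O)N/N=C/c2ccccc2C(F)(F)F)s1`: 8.21 ug/mL

Compound 2 stands at the upper of the two numbers, but its step from compound 1 is a 1.1-fold higher number from compound 1 to compound 2 (0.03 log units; within the scatter), so the two values lie within the scatter of each other and no order between them is claimed.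

Compound 3, `CN(C(=O)NC(=O)c1ccc(F)c(F)c1)c1nc(C(F)(F)F)c(C(=O)N/N=C/c2ccc([N+](=O)[O-])cc2)s1`, is the next compound to be measured. The change from compound 2 is 4-nitrophenyl in place of 2-(trifluoromethyl)phenyl on a carbon with a double bond to nitrogen.

Going by the values given here, no measured step touches this position: the one step available, a 1.1-fold higher number from compound 1 to compound 2 (0.03 log units; within the scatter), concerns the aryl group on the carbonyl carbon of the acylurea, not the aryl on the carbon with a double bond to nitrogen, and it was within the scatter. There is thus no basis in the series for expecting a step in this assay beyond the scatter in either direction, and the uncertainty around the estimate is set wide.

Compound 3 is expected to give 8 ug/mL (range 3 ug/mL to 22 ug/mL). The expected step is a 1.0-fold lower number from compound 2 to compound 3 (0.01 log units; within the scatter).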

Compound 3, half-maximal inhibitory concentration: 4.81 ug/mL
Beside the measured number, compound 3's estimate is 1.7-fold (0.22 log units) above it; the measured number falls inside the stated range.
By their numbers in this assay, from the lowest: compounds 3, 1 and 2 (each within the scatter of the next).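

In this assay, going by these compounds alone, the exchange of 4-nitrophenyl for 2-(trifluoromethyl)phenyl gives a 1.7-fold lower number from compound 2 to compound 3 (0.23 log units; within the scatter), the first reading at the carbon with a double bond to nitrogen. Within this pair, the position accepts a change of both the substituent and its place on the aryl ring without a step beyond the scatter, although the two effects cannot be separated from this single exchange. No measurement at hand bears on the reason for this result.

Still open, as far as these compounds go, is whether the same holds for an unsubstituted phenyl, for a phenyl carrying an amine or a carboxylic acid, or for a non-aromatic group such as a longer alkyl chain at this carbon, any of which could show whether the position has a real effect on the read-out in this assay. Within the data shown here, also open is whether 4-nitrophenyl behaves the same way when the carbonyl carbon of the acylurea carries 3-(trifluoromethyl)phenyl, as no pair yet tests the two positions together.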